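This account rests on a few compounds, and the source may have more. Where it says the series, first, only, none or still open, it means among the compounds named here.

Compound 3 `Brc1ccc(-c2nnc(Cn3nnc4ccccc43)o2)cc1` is tested in an ADME assay on cells (Macrophage, Homo sapiens) for inhibition; a higher number here means that more compound is tolerated, a lower number that less compound is tolerated. In this assay compound 3 gives > 100000 nM, which is a limit of the assay and not a number. Compound 1 `Brc1ccc(Cc2nnc(Cn3nnc4ccccc43)o2)cc1` likewise gives > 100000 nM in this assay, again a limit. Compound 2 `Brc1cccc(-c2nnc(Cn3nnc4ccccc43)o2)c1` gives > 100000 nM in this assay, also a limit. The step that the two limits leave unreadable from compound 2 to compound 3 cannot be read, as the limit of > 100000 nM in this assay, at which 3 of the 3 values shown sit, shows where all three values sit. Compound 4 `Fc1cccc(-c2nnc(Cn3nnc4ccccc43)o2)c1` differs from compound 3 by 3-fluorophenyl in place of 4-bromophenyl on an aromatic carbon. Going by the values given here, no measured step reads on this change, since every value shown is a limit. Compound 4 is therefore expected to stay at that same limit, with an expected step of a number no higher from compound 3 to compound 4 (the limit leaves the size open). The value of compound 4 is estimated at 100000 nM, within a range from 50000 nM to 200000 nM.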

Compound 4, half-maximal cytotoxic concentration: > 100000 nM
Compound 4 was reported as a limit; the forecaster's own chance of this, stated with the estimate: 85%; the middle value lies on the limit itself.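

Going by these compounds alone, no step among compound 2, compound 3 and compound 4 can be read in this assay, where each value is a limit and not a number: the limit of > 100000 nM in this assay, at which 4 of the 4 values shown sit.

The compounds shown leave open whether any change on the shared core alters the concentration tolerated in this assay.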